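From Cyclohexyl to Furan-2-yl on a Pyranone Core

The source may hold more compounds than are shown below. What is called first, only, known or untested is meant among the compounds shown, and "the series" means these compounds.

Of the compounds shown here, three sharing one core have been tested in a functional assay on KBVIN cells (Homo sapiens) for cytotoxicity, read by MTT assay, with a stated time of 72 h; on this read-out lower numbers stand for an effect already at smaller amounts and higher numbers for an effect only at larger amounts of compound. Compound 1 `O=c1cc(NC2CCCCC2)cc(/C=C/c2ccccc2)o1` gives 1.24 uM, compound 2 `COc1ccc(Nc2cc(C3CCCCC3)oc(=O)c2)cc1` gives 4.39 uM, and compound 3 `O=c1cc(Nc2ccccc2)cc(-c2ccccc2)o1` gives 0.15 uM. On these numbers compound 2 stands highest: its number lies beyond the scatter above that of compound 1 and far beyond the scatter above that of compound 3, so it is the weakest of the three in this assay.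

Compound 4 `COc1ccc(Nc2cc(-c3ccco3)oc(=O)c2)cc1` is not yet measured. It differs from compound 2 in one place: furan-2-yl in place of cyclohexyl on an aromatic carbon. Among the compounds with values here, no measured pair shows this exact change, so its size can only be guessed. Because compound 3 gives 0.15 uM and compound 1 gives 1.24 uM, both well below compound 2, the step from compound 2 to compound 4 is expected to go downward, toward a stronger effect, by more than the scatter, as a 3.7-fold lower number from compound 2 to compound 4 (0.56 log units; beyond the scatter). Compound 4 is therefore expected to give about 1.2 uM in this assay, with a likely range from 0.4 uM to 4 uM.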

Compound 4, concentration for half-maximal effect: 1.46 uM
Beside the measured number, compound 4's estimate is 1.2-fold (0.09 log units) below it; the measured number falls inside the stated range.
By their numbers in this assay, from the lowest: compound 3; then compounds 1 and 4 (each within the scatter of the next); then compound 2.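

Within the data shown here, this is the first step on the shared core that isolates a single change: furan-2-yl in place of cyclohexyl, on the aromatic carbon next to the ring oxygen, gives a 3.0-fold lower number from compound 2 to compound 4 (0.48 log units; beyond the scatter) in this assay. The position therefore responds to what it carries, and the five-membered aromatic ring goes with the lower number, though the step is modest and rests on this one pair. Nothing measured here says why the two groups differ.

Thiophen-2-yl in this place, with sulfur in the ring instead of oxygen, would help show whether the oxygen of furan-2-yl matters or only the aromatic ring. On these data alone, how a methyl group or an open butyl chain would compare on the core of compound 4 also remains open.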